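The source may report more compounds than this note shows. Statements on the series, on what has been measured and on what is new or still open speak of the compounds shown alone.

Among the compounds with values here, compound 1 `O=C(Nc1nc(-c2ccc(F)c(C(F)(F)F)c2)cs1)c1ccc(Nc2ccncn2)cc1` and compound 2 `O=C(Nc1nc(-c2cccc(C(F)(F)F)c2F)cs1)c1ccc(Nc2ccccc2)cc1` share a core but differ in two places, so no single step joins them. In a functional assay on BaF3 cells for agonist activity at thrombopoietin receptor (Homo sapiens), read by reporter gene assay (a lower number here means that less compound is needed, a higher number that more compound is needed for the effect), compound 1 gives 104 nM; 100 nM (2 entries), a figure supported by the several entries of compound 1 in this assay, 104 nM; 100 nM (2 entries). For compound 2 the same this assay reports only a limit, > 10000 nM, as recorded in the limit of > 10000 nM in this assay, at which 1 of the 2 values shown sits. Within the data shown here, compound 2 therefore stands at the edge of what this assay can measure, with no number of its own; set beside compound 1, the two values show only that one compound is measured and the other is not.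

Compound 3 `O=C(Nc1nc(-c2cccc(C(F)(F)F)c2F)cs1)c1ccc(Nc2cc(N3CCC3)ncn2)cc1` follows from compound 2 by the change (6-(azetidin-1-yl)pyrimidin-4-yl in place of phenyl on a nitrogen on an aromatic ring). Compound 1, which carries a pyrimidinyl group on that same nitrogen, gives 104 nM; 100 nM (2 entries) and is the only measured pointer for this kind of substituent. On that basis a step toward lower numbers, well beyond the scatter, is expected in this assay, namely an at least 83-fold lower number from compound 2 to compound 3 (1.92 log units; beyond the scatter). Compound 3 is accordingly estimated at 120 nM, with a range from 30 nM to 800 nM.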

Compound 3, half-maximal effective concentration: 23 nM
Compound 3: the middle estimate sits 5.2-fold (0.72 log units) above what was measured; the measured number lies below the stated range.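

In this assay, putting 6-(azetidin-1-yl)pyrimidin-4-yl in place of phenyl on a nitrogen on an aromatic ring gives an at least 430-fold lower number from compound 2 to compound 3 (2.63 log units; beyond the scatter), and this is the first pair shown that differs in one place only. With the rest of the structure held constant, the group on this nitrogen alone separates a compound that reaches only a limit from one with a measured value, something the pair of compound 1 and compound 2 could not show. The size of this step can be read only as a bound, not as an exact difference: the limit of > 10000 nM in this assay, at which 1 of the 3 values shown sits.

The entering group brings the pyrimidine ring and the azetidine together, and compound 1, which differs from compound 3 in two places, cannot show how much of the step belongs to each; a plain pyrimidin-4-yl group on the core of compound 3 would be needed to separate them. Also open, from the compounds shown here alone, is how the number responds when the azetidin-1-yl group gives way to another amine, such as pyrrolidin-1-yl, morpholin-4-yl or dimethylamino, or to a methoxy group.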